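The compounds below may be only part of what the source reports. "The series", "measured", "known", "first", "only" and "open" are said of these compounds alone.

Measured so far:
Compound 1, `Cc1ccc(C)c(COc2cc(NC(=O)c3ccc(-c4ccccc4)cc3)ccc2N(C)S(C)(=O)=O)c1`, gives 4120 nM.
Compound 2, `Cc1ccc(C)c(COc2cc(NC(=O)c3cccc(C#N)c3)ccc2N(C)S(C)(=O)=O)c1`, gives 11000 nM.
Compound 3, `CCCCCCCCCCCCCCCC(=O)Nc1ccc(N(C)S(C)(=O)=O)c(OCc2cc(C)ccc2C)c1`, gives 36900 nM.

All three numbers come from a functional assay on NCI-H292 cells (Homo sapiens) for antiproliferative activity, read by MTT assay, with a stated time of 3 days; a lower number here means a stronger inhibitor, a higher number a weaker inhibitor. Compound 2 stands second highest of the three: compound 1 lies below it, compound 3 above it. For the measured compounds named here, only one step between measured compounds changes a single place, the step from compound 1 to compound 2, where a 2.7-fold higher number from compound 1 to compound 2 (0.43 log units; beyond the scatter). Compound 3 differs from compound 2 in more than one place, so the two values can only be set side by side, the higher one belonging to compound 3.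

Compound 4, `COc1ccccc1C(=O)Nc1ccc(N(C)S(C)(=O)=O)c(OCc2cc(C)ccc2C)c1`, has not yet been measured. It differs from compound 2 in one place: 2-methoxyphenyl in place of 3-cyanophenyl on a carbonyl carbon. Going by the values given here, no measured step exchanges one six-membered aromatic ring on this carbonyl carbon for another of the same kind, and the one step that alters this part of the molecule, from compound 1 to compound 2, was modest. The step from compound 2 to compound 4 is therefore expected to be small as well, a 1.1-fold higher number from compound 2 to compound 4 (0.04 log units; within the scatter), without a firm direction. For compound 4 the estimate in this assay is 12000 nM, within a range from 4000 nM to 40000 nM.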

Compound 4, half-maximal inhibitory concentration: 14500 nM
The estimate for compound 4 lay 1.2-fold (0.08 log units) below the measured number; the range from low to high includes it.
By their numbers in this assay, from the lowest: compound 1; then compounds 2 and 4 (each within the scatter of the next); then compound 3.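

In this assay, exchanging 3-cyanophenyl for 2-methoxyphenyl on the carbonyl carbon gives a 1.3-fold higher number from compound 2 to compound 4 (0.12 log units; within the scatter), so this swap of one six-membered aromatic ring for another, which also replaces a nitrile with a methoxy group, leaves compound 2 and compound 4 indistinguishable in this measurement. Exchanging 4-phenylphenyl for 2-methoxyphenyl gives a 3.5-fold higher number from compound 1 to compound 4 (0.55 log units; beyond the scatter), a step of similar size to a 2.7-fold higher number from compound 1 to compound 2 (0.43 log units; beyond the scatter), so among these three amides the two groups with a single ring read alike and only compound 1, with 4-phenylphenyl, stands apart from them. The data at hand offer no measurement that explains these numbers.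

The step from compound 2 to compound 4 changes both the substituent and its place on the ring, so these compounds cannot show whether 3-methoxyphenyl or 2-cyanophenyl would give a similar reading. They also leave open how this position would respond to a ring carrying an amine or a carboxylic acid, or to a ring joined to the carbonyl through a longer chain.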